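The source may report more compounds than this note shows. Statements on the series, on what has been measured and on what is new or still open speak of the compounds shown alone.

Compound 1 `O=C(NC1CCCCC1)C1CCN(Cc2ccccc2)CC1` gives 15 nM in an assay for displacement of a labelled ligand from Sigma non-opioid intracellular receptor 1 (Cavia porcellus); on this read-out higher numbers stand for weaker inhibition and lower numbers for stronger inhibition. Compound 2 `CC(C)NC(=O)C1CCN(Cc2ccccc2)CC1` differs from it by isopropyl in place of cyclohexyl on an amide-type nitrogen, and in this assay compound 2 gives 1070 nM, a step of a 71-fold higher number from compound 1 to compound 2 (1.85 log units; beyond the scatter). Compound 3 `O=C(NC1CCCCC1)C1CCN(Cc2ccc(Cl)cc2Cl)CC1` carries a different core: it differs from compound 1 by 2,4-dichlorophenyl in place of phenyl on a saturated chain carbon bound to an amine nitrogen in a ring, and in this assay compound 3 gives 52 nM, a step of a 3.5-fold higher number from compound 1 to compound 3 (0.54 log units; beyond the scatter). Compound 4 `CC(C)NC(=O)C1CCN(Cc2ccc(Cl)cc2Cl)CC1` has not yet been measured; it differs from compound 3 by isopropyl in place of cyclohexyl on an amide-type nitrogen, the same change that separates compound 2 from compound 1. Because compound 1 to compound 2 gave a 71-fold higher number from compound 1 to compound 2 (1.85 log units; beyond the scatter), a step of similar size is expected from compound 3 to compound 4, namely a 58-fold higher number from compound 3 to compound 4 (1.76 log units; beyond the scatter). On that basis compound 4 is estimated at 3000 nM in this assay, most likely between 800 nM and 12000 nM.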

Compound 4, inhibition constant: > 2000 nM
Compound 4: no number, only a limit; the forecaster's own chance of this, stated with the estimate: 10%; the middle value is on the limit's open side.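

In this assay compound 4 returns only a limit, > 2000 nM, and not a number. Even so, replacing cyclohexyl with isopropyl on the amide-type nitrogen also gives a large step on the second core, an at least 38-fold higher number from compound 3 to compound 4 (1.58 log units; beyond the scatter), so the direction of the change and its large size carry over between these two cores: the same change on two cores in this assay, a 71-fold higher number (1.85 log units; beyond the scatter) from compound 1 to compound 2 and an at least 38-fold higher number (1.58 log units; beyond the scatter) from compound 3 to compound 4; the limit leaves it open whether they differ This does not show the exact size of the step on the core of compound 3, nor whether the change costs more or less there than on the core of compound 1.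

The compounds shown leave open how cyclopentyl or a longer chain on the amide-type nitrogen would behave. They also leave open whether the step would hold if the phenyl carried a methoxy group instead of the chlorines.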